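Moving a chlorine around a pyridinyl ring and solubility

The source may hold more compounds than are shown below. What is called first, only, known or untested is meant among the compounds shown, and "the series" means these compounds.

Measured so far:
compound 1 `Cn1c(COc2cccc(C(=O)O)c2)nc2cnc(Oc3ccc4c(c3)CCC4)cc21` gives 70 ug/mL in a physicochemical assay for solubility, read by HPLC, measured as thermodynamic solubility, with a stated time of 4 h, at pH 6.8; on this read-out lower numbers stand for lower solubility and higher numbers for higher solubility;
compound 2 `Cn1c(COc2cccc(C(=O)O)c2)nc2ccc(Oc3ccccn3)cc21` gives 62 ug/mL in this assay;
compound 3 `Cn1c(COc2cccc(C(=O)O)c2)nc2ccc(Oc3cccc(Cl)n3)cc21` gives 7.7 ug/mL in this assay.

Compound 3 stands lowest of the three measured numbers: compound 2 sits nearest, an 8.1-fold lower number from compound 2 to compound 3 (0.91 log units; beyond the scatter), and compound 1 furthest. Compound 4 `Cn1c(COc2cccc(C(=O)O)c2)nc2ccc(Oc3ccc(Cl)cn3)cc21` differs from compound 3 by 5-chloropyridin-2-yl in place of 6-chloropyridin-2-yl on an oxygen on an aromatic ring. For the measured compounds named here, no measured step rearranges the same atoms this way; the only step that touches this ring, the one from compound 2 to compound 3, added a chlorine and is therefore of limited bearing. The expectation is that the step of a 1.2-fold higher number from compound 3 to compound 4 (0.07 log units; within the scatter) stays within the scatter. Compound 4 is estimated at 9 ug/mL, with a likely range from 3 ug/mL to 27 ug/mL.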

Compound 4, solubility: 17 ug/mL
Beside the measured number, compound 4's estimate is 1.9-fold (0.28 log units) below it, within the range that was stated.
By their numbers in this assay, from the lowest: compound 3; then compound 4; then compounds 2 and 1 (each within the scatter of the next).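

Swapping 6-chloropyridin-2-yl for 5-chloropyridin-2-yl on the oxygen keeps the same atoms yet gives a 2.2-fold higher number from compound 3 to compound 4 (0.34 log units; beyond the scatter) in this assay, so the two chlorinated isomers are distinguishable on this read-out. Chloro in place of hydrogen still gives a 3.6-fold lower number from compound 2 to compound 4 (0.56 log units; beyond the scatter), so the lower number seen with an 8.1-fold lower number from compound 2 to compound 3 (0.91 log units; beyond the scatter) recurs with the chlorine placed differently, though the size of the step is not the same. Nothing available explains the difference between these two isomers. Going by these compounds, whether a methoxy group or a fluorine in place of the chloro would follow the same order remains open.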